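Changing the aryl group on sulfur: compound 2 to compound 3

This account rests on a few compounds, and the source may have more. Where it says the series, first, only, none or still open, it means among the compounds named here.

Two measured compounds frame this step. In a functional assay on HCT-116 cells (Homo sapiens) for inhibition, read by CCK-8 assay, with a stated time of 72 h, tested at 2 uM (a higher number here means more inhibition of growth at the concentration tested, a lower number less inhibition of growth), compound 1 `Nc1ccccc1NC(=O)/C=C/c1ccc(CSc2cccc(F)c2)cc1` gives 7.95% and compound 2 `Nc1ccccc1NC(=O)/C=C/c1ccc(CSc2ccc(C(F)(F)F)cn2)cc1` gives 4.42%. These two values lie within the scatter of each other, so compound 2 cannot be separated from compound 1 on these numbers.

The step leads to compound 3 `Cc1ccc(SCc2ccc(/C=C/C(=O)Nc3ccccc3N)cc2)cc1`, with 4-methylphenyl in place of 5-(trifluoromethyl)pyridin-2-yl on a sulfur. Among the compounds with values here, one measured step bears on this, also a change of the group on that sulfur: a number 3.5 percentage points lower from compound 1 to compound 2 (within the scatter). Its size gives no sign that such a change moves this assay beyond the scatter, though a single step is thin evidence. The entering group is, like the 3-fluorophenyl of compound 1 at 7.95%, a six-membered aromatic ring of carbon only, so the expectation leans slightly toward that value.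

The estimated move is a number 2.6 percentage points higher from compound 2 to compound 3 (within the scatter), and no step beyond the scatter is expected. For compound 3 the estimated value is 7%, with an expected range of 0% to 18%.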

Compound 3, percent growth inhibition at one concentration: 6.23%
Estimate against measurement, compound 3: 0.8 percentage points above; low and high end bracket the measured number.
By their numbers in this assay, from the lowest: compounds 2, 3 and 1 (each within the scatter of the next).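

In this assay, exchanging 5-(trifluoromethyl)pyridin-2-yl for 4-methylphenyl on a sulfur whose other neighbour is a saturated chain carbon gives a number 1.8 percentage points higher from compound 2 to compound 3 (within the scatter), and exchanging 3-fluorophenyl for 4-methylphenyl at the same place gives a number 1.7 percentage points lower from compound 1 to compound 3 (within the scatter), so all three groups now sit within the scatter of one another. The step from compound 2 to compound 3 also takes the group from 10 heavy atoms with 1 hydrogen-bond acceptor and a hetero atom in the ring to 7 heavy atoms of carbon only with no acceptor, and that difference comes with no step beyond the scatter in this series of aromatic rings on sulfur. No measurement at hand offers an explanation for these numbers.

Open, as far as these compounds go, is whether a group of another kind on that sulfur, such as a 4-aminophenyl, a 4-carboxyphenyl or a longer alkyl chain, would move the number beyond the scatter in this assay at all. Also open, from the compounds shown here alone, is whether an oxygen in place of the sulfur, with the 4-methylphenyl kept, would leave the reading within the same scatter.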